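A few compounds are considered here, and "the series" means these few. Any claim that something is new, unique, unknown or untested is made for them only; others in the source may bear on it.

In a physicochemical assay for solubility, read by HPLC, in phosphate buffer, measured as kinetic solubility, with a stated time of 1 h, at pH 7.4, tested at 250 uM (on this read-out lower numbers stand for lower solubility and higher numbers for higher solubility), compound 1 (`CCCCCNC(=O)n1cc(-c2ccccc2)oc1=O`) gives < 1000 nM, a limit and not a number. Compound 2 (`CC(C)CNC(=O)n1cc(-c2ccccc2)oc1=O`) gives < 1000 nM, also a limit. Compound 3 (`O=C(NCCCCc1ccccc1)n1cc(-c2ccc(F)cc2)oc1=O`) gives < 1000 nM, again a limit. All three compounds stand at the limit of < 1000 nM in this assay, at which 3 of the 3 values shown sit. Compound 4 (`O=C(NCCCCc1ccccc1)n1cc(-c2cccnc2)oc1=O`) carries pyridin-3-yl in place of 4-fluorophenyl on an aromatic carbon. Among the measured compounds shown here, the only step between measured compounds, a step that the two limits leave unreadable from compound 1 to compound 2, concerns the chain on the amide-type nitrogen and supplies no size for this change. A modest upward step in this assay is nevertheless expected, estimated as an at least 2.0-fold higher number from compound 3 to compound 4 (0.30 log units; that floor lies within the scatter), with wide uncertainty. Compound 4 is estimated at 2000 nM. The expected range for compound 4 runs from 400 nM to 10000 nM.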

Compound 4, solubility: < 1000 nM
Compound 4 ended at the assay's limit; the forecaster's own chance of this, stated with the estimate: 45%; middle value at least 2.0-fold (0.30 log units) away from the limit.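

Among the compounds shown here, compound 3 and compound 4 both stand at a limit, so no step between them can be read in this assay: the limit of < 1000 nM in this assay, at which 4 of the 4 values shown sit. The compounds shown leave open whether any change to the shared core gives a number rather than a limit in this assay.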